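The source may report more compounds than this note shows. Statements on the series, on what has been measured and on what is new or still open speak of the compounds shown alone.

Measured compounds:
compound 1 `O=c1[nH]cc(S(=O)(=O)Nc2ccccc2-c2cn(-c3ccccc3)nn2)c(=O)[nH]1` with 6790 nM
compound 2 `Cc1ccc(-n2cc(-c3ccccc3NS(=O)(=O)c3c[nH]c(=O)[nH]c3=O)nn2)cc1` with 2910 nM

Among the measured compounds shown here, in a functional assay on A549 cells (Homo sapiens) for antiproliferative activity, read by MTT assay, with a stated time of 24 h (a higher number here means a weaker inhibitor, a lower number a stronger inhibitor), compound 2 gives the lowest of the two numbers known so far. For the measured compounds named here, its only neighbour is compound 1, which gives 6790 nM, and the step of a 2.3-fold lower number from compound 1 to compound 2 (0.37 log units; beyond the scatter) lies beyond the scatter, though it is modest. Compound 3 `O=c1[nH]cc(S(=O)(=O)Nc2ccccc2-c2cn(-c3cccc(F)c3)nn2)c(=O)[nH]1` has not yet been measured. Compared with compound 2 it carries 3-fluorophenyl in place of 4-methylphenyl on an aromatic nitrogen. Going by the values given here, the one measured step that bears on this change is a 2.3-fold lower number from compound 1 to compound 2 (0.37 log units; beyond the scatter), which shows what a methyl on the phenyl attached to that ring nitrogen did against the bare phenyl of compound 1. Among the compounds with values here, no measured pair shows a fluorine on that phenyl, and no step compares two different substituents there. Within the data shown here, compound 3 thus has no direct precedent; the reasonable expectation is a number between those of compound 1 and compound 2, with a small upward drift away from compound 2 that may well stay within the scatter. Compound 3 is expected to give 4500 nM in this assay, within 2000 nM to 10000 nM. The estimated step of a 1.5-fold higher number from compound 2 to compound 3 (0.19 log units; within the scatter) is accordingly small.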

Compound 3, half-maximal inhibitory concentration: 8130 nM
Compound 3: middle estimate off by 1.8-fold (0.26 log units), on the low side; the measured number falls inside the stated range.
By their numbers in this assay, from the lowest: compound 2; then compounds 1 and 3 (each within the scatter of the next).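

At the aromatic nitrogen of the five-membered aromatic ring, the lower number seen with 4-methylphenyl does not carry over to every substituted phenyl: in this assay, exchanging 4-methylphenyl for 3-fluorophenyl gives a 2.8-fold higher number from compound 2 to compound 3 (0.45 log units; beyond the scatter), a modest step that returns the number to the level of the bare phenyl. Set against that bare phenyl, the fluorine gives a 1.2-fold higher number from compound 1 to compound 3 (0.08 log units; within the scatter), so compound 3 cannot be told apart from compound 1, and a substituent on this phenyl does not by itself separate a compound from compound 1; among these three compounds, only compound 2 does so. No supporting measurement is available to explain the difference between these groups.

The step from compound 2 to compound 3 changes both the substituent and its place on the phenyl, so these compounds cannot show which of the two matters. They also leave open whether a methoxy group, an amine or a carboxylic acid on this phenyl would move the number further from that of compound 1, in either direction.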